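A few compounds are considered here, and "the series" means these few. Any claim that something is new, unique, unknown or untested is made for them only; others in the source may bear on it.

Working notes on the series. In a functional assay on A549 cells (Homo sapiens) for inhibition, read by CCK-8 assay, with a stated time of 72 h, tested at 10 uM (a higher number here means more inhibition of growth at the concentration tested, a lower number less inhibition of growth), compound 1 `COC(=O)c1ccc(NC(=O)C2(C(=O)Nc3ccc(Nc4ncc5cc(C(=O)N(C)C)n(C6CCCC6)c5n4)cc3)CC2)cc1` gives 92%, compound 2 `Cc1ccc(NC(=O)C2(C(=O)Nc3ccc(Nc4ncc5cc(C(=O)N(C)C)n(C6CCCC6)c5n4)cc3)CC2)cc1` gives 90.6% and compound 3 `COc1cccc(NC(=O)C2(C(=O)Nc3ccc(Nc4ncc5cc(C(=O)N(C)C)n(C6CCCC6)c5n4)cc3)CC2)c1` gives 96%. Compound 3 therefore stands level with the other two within the scatter, as shown by a number 4 percentage points higher from compound 1 to compound 3 (within the scatter) and a number 5.4 percentage points higher from compound 2 to compound 3 (within the scatter). Compound 4 `CN(C)C(=O)c1cc2cnc(Nc3ccc(NC(=O)C4(C(=O)Nc5ccc(C(F)(F)F)cc5)CC4)cc3)nc2n1C1CCCC1` carries one change relative to compound 3: 4-(trifluoromethyl)phenyl in place of 3-methoxyphenyl on an amide-type nitrogen. This places 4-(trifluoromethyl)phenyl in place of 3-methoxyphenyl on an amide-type nitrogen. The measured steps at this part of the molecule, including a number 1.4 percentage points lower from compound 1 to compound 2 (within the scatter), all stay within the scatter, so no step beyond the scatter is expected in this assay. The expected step is a number 5 percentage points lower from compound 3 to compound 4 (within the scatter). For compound 4 the estimated value is 91%, with an expected range of 80% to 99%.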

Compound 4, percent growth inhibition at one concentration: 87.9%
The estimate for compound 4 lay 3.1 percentage points above the measured number; the range from low to high includes it.
By their numbers in this assay, from the lowest: compounds 4, 2, 1 and 3 (each within the scatter of the next).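

In this assay, 4-(trifluoromethyl)phenyl on the amide-type nitrogen, with no hydrogen-bond acceptor, stands level with 3-methoxyphenyl, with one (a number 8.1 percentage points lower from compound 3 to compound 4 (within the scatter)). Trifluoromethyl in place of methyl (a number 2.7 percentage points lower from compound 2 to compound 4 (within the scatter)) and in place of methoxycarbonyl (a number 4.1 percentage points lower from compound 1 to compound 4 (within the scatter)) likewise leaves the number unresolved, so all three groups on this aromatic carbon read alike among these compounds. No evidence bears on why these compounds read alike.

Going by these compounds, whether an amine or a carboxylic acid on this ring would give a step beyond the scatter remains open. Also open is whether the level numbers at one concentration hide differences among these compounds.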